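Replacing Methyl with 2-Aminophenyl on the Amide Nitrogen

The compounds below may be only part of what the source reports. "The series", "measured", "known", "first", "only" and "open" are said of these compounds alone.

Compound 1 `CC(C)c1ccc(-n2nc(-c3ccccc3)nc2CNc2ccc(C(=O)NO)cc2)cc1` in an assay on Sf9 cells for inhibition of protein deacetylase HDAC6 (Homo sapiens), read by fluorescence, with a stated time of 40 min, tested at 100 nM (a lower number here means less inhibition, a higher number more inhibition at the concentration tested (going by the name of the read-out)), gives 52.6%.
Compound 2 `CNC(=O)c1ccc(NCc2nc(-c3ccccc3)nn2-c2ccccc2)cc1` in this assay gives -3.6%.
Compound 3 `Cc1ccc(-n2nc(-c3ccccc3)nc2CNc2ccc(C(=O)NO)cc2)cc1C` in this assay gives 53%.

Compound 2 stands lowest of the three numbers; compound 1 and compound 3 both lie beyond the scatter above it, and the step of a number 0.4 percentage points higher from compound 1 to compound 3 (within the scatter) between those two changes a group on an aromatic nitrogen, not the amide nitrogen. Compound 4 `Nc1ccccc1NC(=O)c1ccc(NCc2nc(-c3ccccc3)nn2-c2ccccc2)cc1` differs from compound 2 by 2-aminophenyl in place of methyl on an amide-type nitrogen. Among the compounds with values here, no measured step touches this place, so the expectation rests on the value of compound 2 alone, -3.6%. Compound 4 is therefore expected to show only a small rise, a number 9.6 percentage points higher from compound 2 to compound 4 (within the scatter), likely within the scatter. Compound 4 is estimated at 6%, with a range from -10% to 25%.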

Compound 4, a percentage reported as inhibition, at one concentration (the size of the read-out at that concentration, not a potency): 5%
For compound 4 the middle estimate is 1 percentage points above the measured one; the measured number falls inside the stated range.
By their numbers in this assay, from the lowest: compounds 2 and 4 (each within the scatter of the next); then compounds 1 and 3 (each within the scatter of the next).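

In this assay, 2-aminophenyl in place of methyl on the amide-type nitrogen gives a number 8.6 percentage points higher from compound 2 to compound 4 (within the scatter), so the two numbers cannot be told apart. At this position, adding a six-membered aromatic ring and an amino group therefore brings no clear gain in inhibition at the concentration tested. No supporting evidence bears on this result. On these data alone, whether a plain hydrogen, a 2-hydroxyphenyl group or a longer carbon chain on this nitrogen would give a different number remains open. So does the behaviour of compound 4 at any other concentration.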